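Swapping chlorines for fluorines on a chalcone-like pyrazole

A few compounds are considered here, and "the series" means these few. Any claim that something is new, unique, unknown or untested is made for them only; others in the source may bear on it.

Compound 1 `COc1cc(-c2cc(/C=C/C(=O)c3ccc(Cl)c(Cl)c3)[nH]n2)cc(OC)c1OC` was tested in a functional assay on OVCAR-4 cells (Homo sapiens) for cytotoxicity, read by sulforhodamine B assay, with a stated time of 48 h, tested at 100 uM (a higher number here means a weaker effect of the compound at the concentration tested, a lower number a stronger effect), where compound 1 gives -22%. Within the data shown here, of the two compounds measured so far, compound 1 stands highest, meaning the weaker effect at the tested concentration. The other, compound 2 `COc1cc(C(=O)/C=C/c2cc(-c3cc(OC)c(OC)c(OC)c3)n[nH]2)cc(OC)c1OC`, carries the same three methoxy groups and the same pyrazole core but links them in a different arrangement, and in this assay compound 2 gives -98%, a number far below that of compound 1 and beyond the usual scatter.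

Among the measured compounds shown here, the next compound, compound 3 `COc1cc(-c2cc(/C=C/C(=O)c3ccc(F)c(F)c3)[nH]n2)cc(OC)c1OC`, keeps the whole skeleton of compound 1 and changes only one group: 3,4-difluorophenyl in place of 3,4-dichlorophenyl on a carbonyl carbon. For the measured compounds named here, no measured pair shows what such a swap of one halogen pair for another does here, so the expectation rests on compound 1 alone. The step from compound 1 to compound 3 is expected to be small, a number 10 percentage points higher from compound 1 to compound 3 (within the scatter), with no clear direction beyond the scatter. Compound 3 is therefore estimated to give about -12% in this assay, within a range from -48% to 24%.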

Compound 3, a percentage reported as activity, at one concentration (the size of the read-out at that concentration, not a potency): -3%
Compound 3: middle estimate off by 9 percentage points, on the low side; the measured number falls inside the stated range.
By their numbers in this assay, from the lowest: compound 2; then compound 1; then compound 3.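

Among these compounds, this is the first measured change at this place, a carbonyl carbon bearing a halogenated phenyl ring. In this assay the swap of 3,4-dichlorophenyl for 3,4-difluorophenyl gives a number 19 percentage points higher from compound 1 to compound 3 (beyond the scatter) and so a weaker effect at the tested concentration. The two groups have the same heavy-atom count and the same ring and differ only in their halogen pair, so the identity of the halogens alone is enough to shift this read-out, though the data offer no measured explanation for the shift.

From the compounds shown here alone, it remains open what this assay would show for a phenyl ring carrying a nitrile, an amine or a carboxylic acid in place of the two halogens. Going by these compounds, whether the same halogen swap would have a similar effect on a different core also remains unknown.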